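Aryl ketone dithiocarbamate series: heteroaryl in place of hydroxyphenyl

The source may hold more compounds than are shown below. What is called first, only, known or untested is meant among the compounds shown, and "the series" means these compounds.

Measured compounds:
compound 1, `CN(C)C(=S)SCC(CSC(=S)N(C)C)C(=O)c1ccccc1` — 1930 nM
compound 2, `CN(C)C(=S)SCC(CSC(=S)N(C)C)C(=O)c1ccc(O)cc1` — 30000 nM

In a functional assay on NCI-H460 cells (Homo sapiens) for inhibition, read by MTT assay, with a stated time of 72 h (on this read-out lower numbers stand for stronger inhibition and higher numbers for weaker inhibition), compound 2 stands highest of the two numbers; the nearest compound, compound 1, sits a long way below it, as shown by a 16-fold higher number from compound 1 to compound 2 (1.19 log units; beyond the scatter), the only measured step in the set. That step, hydroxy in place of hydrogen on an aromatic carbon, is large and beyond the scatter.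

Compound 3, `CN(C)C(=S)SCC(CSC(=S)N(C)C)C(=O)c1cccnc1`, is not yet measured. Its change from compound 2 is pyridin-3-yl in place of 4-hydroxyphenyl on a carbonyl carbon. Within the data shown here, the hydroxy that entered in a 16-fold higher number from compound 1 to compound 2 (1.19 log units; beyond the scatter) leaves again, which bears directly on the expectation; the ring nitrogen that enters has no measured counterpart in the set, so its effect is unknown. A step back down, though not necessarily to the level of compound 1, is expected: a 6.7-fold lower number from compound 2 to compound 3 (0.82 log units; beyond the scatter). For compound 3 the estimate is 4500 nM, within 1200 nM to 16000 nM.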

Compound 3, half-maximal inhibitory concentration: 870 nM
The estimate for compound 3 lay 5.2-fold (0.71 log units) above the measured number; measured number outside the range, below it.
By their numbers in this assay, from the lowest: compound 3; then compound 1; then compound 2.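

In this assay, the change to pyridin-3-yl gives a 34-fold lower number from compound 2 to compound 3 (1.54 log units; beyond the scatter), a large step that does more than remove the loss seen with 4-hydroxyphenyl. The comparison with the unsubstituted phenyl gives a 2.2-fold lower number from compound 1 to compound 3 (0.35 log units; beyond the scatter), a modest step beyond the scatter, so the carbonyl carbon can carry an aromatic ring with a hetero atom and still reach the lowest number of the three, whereas the earlier pair showed only a rise on substitution. Nothing available accounts for the differences among these three rings.

From the compounds shown here alone, it remains open whether this result is particular to pyridin-3-yl or extends to other rings on the carbonyl carbon, such as thienyl or furyl. Going by these compounds, it is also open whether a methoxy group in place of the hydroxy would give a number as high as that of compound 2.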